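Series notes: aryl swap on the amide-type nitrogen

The source may report more compounds than this note shows. Statements on the series, on what has been measured and on what is new or still open speak of the compounds shown alone.

Among the compounds with values here, compound 3 `Cc1ccccc1NC(=O)NC(CCN(C)C)c1ccc(Cl)cc1` stands highest of the three measured members in an assay on NIH3T3 cells with Urotensin-2 receptor (Homo sapiens) as the target (on this read-out higher numbers stand for larger maximal responses and lower numbers for smaller maximal responses), with 175%. Compound 1 `Cc1cccc(C(=O)NC(CCN(C)C)c2ccc(Cl)cc2)c1C` gives 159% and compound 2 `Cc1ccc(C(=O)NC(CCN(C)C)c2ccc(Cl)cc2)c(C)c1` gives 147% in this assay; the steps of a number 16 percentage points higher from compound 1 to compound 3 (beyond the scatter) and a number 28 percentage points higher from compound 2 to compound 3 (beyond the scatter) both run upward beyond the scatter, while a number 12 percentage points lower from compound 1 to compound 2 (beyond the scatter) runs downward.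

Compound 4 `COc1cccc(NC(=O)NC(CCN(C)C)c2ccc(Cl)cc2)c1` differs from compound 3 by 3-methoxyphenyl in place of 2-methylphenyl on an amide-type nitrogen. Within the data shown here, no measured step changes a group on the amide-type nitrogen, so nothing bears directly on this change. Among the measured compounds shown here, the only step that swaps one substituted phenyl for another, a number 12 percentage points lower from compound 1 to compound 2 (beyond the scatter), was modest and downward, and it sat on a carbonyl carbon rather than on the amide-type nitrogen. A modest step is therefore expected in this assay, more likely downward than upward, and possibly none beyond the scatter. Compound 4 is expected to give 160% in this assay, with a range from 135% to 185%, which corresponds to an expected step of a number 15 percentage points lower from compound 3 to compound 4 (beyond the scatter).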

Compound 4, largest response reached (reported as efficacy), in percent of the reference or control that the assay uses: 146%
Estimate against measurement, compound 4: 14 percentage points above; low and high end bracket the measured number.
By their numbers in this assay, from the lowest: compounds 4 and 2 (each within the scatter of the next); then compound 1; then compound 3.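

On the amide-type nitrogen, the aryl group clearly matters: replacing 2-methylphenyl with 3-methoxyphenyl gives a number 29 percentage points lower from compound 3 to compound 4 (beyond the scatter) in this assay, the first step shown at this position. This single step joins two changes, the substituent and its place on the phenyl ring, and the compounds shown do not separate them. Nothing available explains the drop in maximal response.

Going by these compounds, it remains open whether 3-methylphenyl or 2-methoxyphenyl on this nitrogen would give a value closer to that of compound 3 or of compound 4, which would show which of the two changes carries the step. On these data alone, the response with an unsubstituted phenyl or an aminophenyl group at this position also remains open.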